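A few compounds are considered here, and "the series" means these few. Any claim that something is new, unique, unknown or untested is made for them only; others in the source may bear on it.

Of the compounds shown here, three of a shared core have been measured in an assay on HEK293 cells for positive allosteric modulation of metabotropic glutamate receptor 5 (Homo sapiens), read by FLIPR; on this read-out lower numbers stand for an effect already at smaller amounts and higher numbers for an effect only at larger amounts of compound. Compound 1 `O=S(=O)(c1ccc(Cl)cc1)N1CC(c2nc(-c3cccc(Cl)c3)no2)C1` carries a sulfonyl group on the ring nitrogen; in this assay compound 1 reaches only the limit > 10000 nM, so no number is known for it. Compound 2 `CC1CCC(C(=O)N2CC(c3nc(-c4cccc(Cl)c4)no3)C2)CC1` carries a 4-methylcyclohexyl group on a carbonyl carbon and gives 1500 nM, the higher of the two numbers measured. Compound 3 `O=C([C@H]1CC2CCC1C2)N1CC(c2nc(-c3cccc(F)c3)no2)C1`, with a bicyclic acyl group and a fluorine in place of chlorine on the aryl ring, gives 72 nM, a lower number than compound 2 and beyond the usual scatter. Compound 4 `CC1CCCC(C(=O)N2CC(c3nc(-c4cccc(Cl)c4)no3)C2)C1` has not yet been measured; it is built from the same atoms as compound 2, joined differently: 3-methylcyclohexyl in place of 4-methylcyclohexyl on a carbonyl carbon. Going by the values given here, no measured pair shows the effect of such a shift of a methyl group on the cyclohexyl ring. The step from compound 2 to compound 4 in this assay is therefore expected to be small, with no clear direction, and to stay within the scatter, so that the estimate is no change at the digits printed from compound 2 to compound 4 (within the scatter). For compound 4 the expected value in this assay is 1500 nM, between 500 nM and 4500 nM.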

Compound 4, half-maximal effective concentration: 410 nM
Compound 4: middle estimate off by 3.7-fold (0.56 log units), on the high side, outside the stated range (below it).
By their numbers in this assay, from the lowest: compound 3; then compound 4; then compound 2. At a limit, above all of these: compound 1.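

In this assay, moving only the methyl group on the cyclohexyl ring is enough to matter: 3-methylcyclohexyl in place of 4-methylcyclohexyl on the carbonyl carbon gives a 3.7-fold lower number from compound 2 to compound 4 (0.56 log units; beyond the scatter) with no change in the atoms present. Going by these compounds alone, this pair is the first to show that, at this place on the shared core, the read-out responds to how a group is joined and not only to what it is built from. Nothing measured here gives a reason for this shift.

From the compounds shown here alone, what a plain cyclohexyl ring without a methyl group, or a 2-methylcyclohexyl group, would give at the same place remains open. So does whether a hydroxyl group or an amine on the ring, in place of the methyl group, would fit this trend of two compounds.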